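The source may hold more compounds than are shown below. What is called first, only, known or untested is meant among the compounds shown, and "the series" means these compounds.

Working notes on the series. In a toxicity assay on THP-1 cells (Homo sapiens) for inhibition (on this read-out higher numbers stand for lower toxicity in this test and lower numbers for higher toxicity in this test), compound 3 `COc1ccc(-c2cnc(NC(C)=O)n2C)cc1` gives > 100000 nM as a limit and not a number. Compound 1 `CCCC(=O)Nc1ncc(-c2ccc(OC)cc2)n1C` gives > 100000 nM as a limit too. Compound 2 `COc1ccc(-c2cnc(NC(=O)c3ccc(C)cc3)n2C)cc1` gives > 100000 nM as a limit too. Compound 3 therefore has no number of its own, and it stands with the other two compounds at the limit of > 100000 nM in this assay, at which 3 of the 3 values shown sit, without a readable rank among them.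

Compound 4 `COc1ccc(-c2cnc(NC(=O)c3ccccc3Br)n2C)cc1` has 2-bromophenyl in place of methyl on a carbonyl carbon, and the counted difference is 2-bromophenyl in place of methyl on a carbonyl carbon with the rest of the structure unchanged.

Among the measured compounds shown here, three measured steps bear on this change, and the nearest is a step that the two limits leave unreadable from compound 2 to compound 3 since it also swaps methyl and a substituted phenyl on the carbonyl carbon. The other two are a step that the two limits leave unreadable from compound 1 to compound 2 and a step that the two limits leave unreadable from compound 1 to compound 3 and neither gives a size. For the measured compounds named here, no measured step therefore points to a move, and none beyond the scatter is expected in this assay although a smaller reading cannot be excluded. The expected change is a number no higher from compound 3 to compound 4 (the limit leaves the size open) as an estimate only. Compound 4 is estimated at 100000 nM with an expected range from 40000 nM to 200000 nM. A limit and not a number may well be what compound 4 is expected to give.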

Compound 4, half-maximal cytotoxic concentration: > 100000 nM
Compound 4: only a limit was reported (the forecaster's own chance of this, stated with the estimate: 75%); the middle value sits exactly at the limit.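

No step to compound 4 from compound 1, compound 2 or compound 3 can be read in this assay, and all four compounds stand together at one limit: the limit of > 100000 nM in this assay, at which 4 of the 4 values shown sit.

The compounds shown leave open whether propyl, methyl, 4-methylphenyl and 2-bromophenyl on the carbonyl carbon differ at all on this read-out.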